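The source may hold more compounds than are shown below. What is called first, only, known or untested is meant among the compounds shown, and "the series" means these compounds.

Compound 1 `CCCCCCCCOC(=O)CS(=O)(=O)Nc1c(C(C)C)cccc1C(C)C` gives in an assay on microsomes from intestine for inhibition of acyl-CoA:cholesterol acyltransferase (Oryctolagus cuniculus) (on this read-out lower numbers stand for stronger inhibition and higher numbers for weaker inhibition), only a limit, > 1000 nM, so for compound 1 no number is known. Going by the values given here, compound 2 `CCCCCCCCCCSC(=O)CS(=O)(=O)Nc1c(C(C)C)cccc1C(C)C` gives in this assay 130 nM, the only number so far. Compound 3 `CCCCCCCCCCCCCCCCCCSC(=O)CS(=O)(=O)Nc1c(C(C)C)cccc1C(C)C` carries octyl in place of hydrogen on a saturated chain carbon, ten or more bonds along the chain from a sulfur. Among the compounds with values here, no measured pair so far changes the chain length, so the size of this step rests on no measured step. The expected step of a 1.3-fold lower number from compound 2 to compound 3 (0.11 log units; within the scatter) is taken as small, not clearly beyond the usual scatter, in either direction. For compound 3 the estimate in this assay is 100 nM, with a range from 30 nM to 400 nM.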

Compound 3, half-maximal inhibitory concentration: > 5000 nM
Compound 3 ended at the assay's limit (the forecaster's own chance of this, stated with the estimate: 10%); middle value at least 50-fold (1.69 log units) away from the limit.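

In this assay, going by these compounds alone, this is the first measured step in chain length, and it is large: octyl in place of hydrogen on a saturated chain carbon, ten or more bonds along the chain from a sulfur, gives an at least 38-fold higher number from compound 2 to compound 3 (1.58 log units; beyond the scatter). The chain therefore cannot be lengthened freely at this position, as the added octyl alone separates the two compounds. Compound 3 gives > 5000 nM, which is a limit of the assay and not a number: the limit of > 5000 nM in this assay, at which 1 of the 3 values shown sits.

Where between the chains of compound 2 and compound 3 the number begins to rise remains open. Also open, going by these compounds, is how a shorter chain, or a chain ending in an amine or a carboxylic acid, would read out here.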